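A Larger Aryl Group on the Ring Amide Nitrogen

The compounds below may be only part of what the source reports. "The series", "measured", "known", "first", "only" and "open" are said of these compounds alone.

Compound 1 `CC(C)[C@@H]1CC[C@@H](C)C[C@@]12N(C)C(=O)[C@@H]1[C@H]3C(=O)NC(=O)[C@H]3ON12` is the parent of this pair. Within the data shown here, in a functional assay, with a stated time of 20 min, tested at 2 mg/mL (a lower number here means a weaker effect, a higher number a stronger effect of the compound at the concentration tested), compound 1 gives 58.7%, the lowest of the two numbers known so far. Its nearest neighbour is compound 2 `CC(C)[C@@H]1CC[C@@H](C)C[C@@]12N(C)C(=O)[C@@H]1[C@H]3C(=O)N(c4ccccc4)C(=O)[C@H]3ON12`, which in this assay gives 74.2%. Among the measured compounds shown here, the only measured step, a number 15.5 percentage points higher from compound 1 to compound 2 (beyond the scatter), is the single piece of evidence that bears on the present question. Compound 3 `CC(C)[C@@H]1CC[C@@H](C)C[C@@]12N(C)C(=O)[C@@H]1[C@H]3C(=O)N(c4ccc5ccccc5c4)C(=O)[C@H]3ON12` carries naphthalen-2-yl in place of hydrogen on an amide-type nitrogen in a ring. Because a number 15.5 percentage points higher from compound 1 to compound 2 (beyond the scatter) was a rise beyond the scatter, the same kind of change toward the larger aryl group is expected to bring a step of similar size and in the same direction, estimated as a number 17.3 percentage points higher from compound 1 to compound 3 (beyond the scatter). Compound 3 is therefore expected to give 76% in this assay, within a range from 62% to 88%.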

Compound 3, a percentage reported as activity, at one concentration (the size of the read-out at that concentration, not a potency): 35%
Compound 3: the middle estimate sits 41 percentage points above what was measured; measured number below the stated range.
By their numbers in this assay, from the lowest: compound 3; then compound 1; then compound 2.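

The amide-type nitrogen in the ring does not respond to aryl groups in a single direction. In this assay, naphthalen-2-yl in place of hydrogen brings a number 23.7 percentage points lower from compound 1 to compound 3 (beyond the scatter), the opposite direction from the rise seen with phenyl. Naphthalen-2-yl in place of phenyl brings a number 39.2 percentage points lower from compound 2 to compound 3 (beyond the scatter), so this change not only removes the gain of compound 2 but also leaves compound 3 under the unsubstituted compound 1, and nothing shown accounts for this reversal.

The compounds shown leave open where a benzyl group, a methyl group, or a phenyl ring bearing an amine or a carboxylic acid on this nitrogen would fall. Three compounds also give no general rule for aryl groups at this position.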